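The source may report more compounds than this note shows. Statements on the series, on what has been measured and on what is new or still open speak of the compounds shown alone.

Measured in an ADME assay on HepG2 cells (Homo sapiens) for cytotoxicity, in the presence of a further agent that is not named here; a lower number here means a stronger inhibitor, a higher number a weaker inhibitor:
- compound 1 `Cn1c(Cc2ccccc2C(F)(F)F)nc(C(=O)NCC2CCCCC2)c(O)c1=O` gives > 100000 nM (a limit)
- compound 2 `Cn1c(Cc2ccccc2C(F)(F)F)nc(C(=O)CCc2ccccc2)c(O)c1=O` gives > 100000 nM (a limit)
- compound 3 `Cn1c(Cc2ccccc2C(F)(F)F)nc(C(=O)NCc2ccccc2F)c(O)c1=O` gives > 100000 nM (a limit)

None of these three results is a number. Together they stand at the limit of > 100000 nM in this assay, at which 3 of the 3 values shown sit. Compound 3 is therefore placed only by its limit and has no exact value.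

Compound 4 `Cn1c(Cc2ccccc2C(F)(F)F)nc(C(=O)NCc2ccc(F)cc2)c(O)c1=O` has the same atoms as compound 3, joined differently: 4-fluorophenyl in place of 2-fluorophenyl on a saturated chain carbon bound to an amide-type nitrogen. In words, 4-fluorophenyl stands in place of 2-fluorophenyl on a saturated chain carbon bound to an amide-type nitrogen.

Going by the values given here, two measured steps bear on this part of the molecule: a step that the two limits leave unreadable from compound 1 to compound 3 and a step that the two limits leave unreadable from compound 2 to compound 3. Neither has a readable size, and neither compares the two fluorophenyl groups, so the data give no direct measure of this change. Even so, compound 3 remains at > 100000 nM after those changes, which gives no reason to expect a step beyond the scatter in this assay, and no direction can be named. The expected change is a number no higher from compound 3 to compound 4 (the limit leaves the size open). For compound 4 the estimate is 100000 nM, with an expected range of 50000 nM to 150000 nM, and the assay is expected most probably to report only a limit again.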

Compound 4, half-maximal inhibitory concentration: > 100000 nM
Compound 4: only a limit was reported (the forecaster's own chance of this, stated with the estimate: 85%); the middle value sits exactly at the limit.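

In this assay compound 4 gives > 100000 nM, which is a limit and not a number. The steps to compound 4 from compound 1, compound 2 and compound 3 therefore cannot be read: the limit of > 100000 nM in this assay, at which 4 of the 4 values shown sit. The compounds shown leave open how 2-fluorobenzyl and 4-fluorobenzyl compare, and what exact value any of the four compounds has in this assay.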